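The compounds below may be only part of what the source reports. "The series", "measured", "known", "first", "only" and "open" are said of these compounds alone.

Measured compounds:
Compound 1 `COc1ccc(NC(=O)CSc2nc3c(OC(C)C)nc(N)nc3[nH]2)cc1OC` gives 11000 nM.
Compound 2 `COc1ccc(NC(=O)CSc2nc3c(=O)[nH]cnc3[nH]2)cc1OC` gives 20 nM.
Compound 3 `COc1ccc(NC(=O)CSc2nc3nccnc3[nH]2)cc1OC` gives 131 nM.

These three values come from an assay on isolated protein for inhibition of Ectonucleotide pyrophosphatase/phosphodiesterase family member 1 (Homo sapiens); on this read-out higher numbers stand for weaker inhibition and lower numbers for stronger inhibition. Compound 1 gives the highest number of the three. Its nearest neighbour on this scale is compound 3, whose number is lower by a gap beyond the scatter, and compound 2 stands further off still with the lowest of the three numbers. Within the data shown here, no two of these measured compounds differ in a single place, so the three values show only that compound 1, with its amino group and isopropoxy on the shared core, inhibits far more weakly than compound 2 and compound 3.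

Compound 4 `COc1ccc(NC(=O)CSc2nc3c(SC)nc(N)nc3[nH]2)cc1OC` has not yet been measured in this assay. It differs from compound 1 in one place: methylsulfanyl in place of isopropoxy on an aromatic carbon. The change is small in count, with the amino group and the rest of the core kept as they are. Among the measured compounds shown here, nothing among the measured compounds shows what this exchange does; no measured pair differs in it. The account therefore expects the step of a 3.1-fold lower number from compound 1 to compound 4 (0.50 log units; beyond the scatter) to run toward a lower number, of a size somewhat beyond the usual scatter, though with wide uncertainty. Compound 4 is estimated at 3500 nM, within a range from 800 nM to 15000 nM.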

Compound 4, inhibition constant: 3650 nM
For compound 4 the middle estimate is 1.0-fold (0.02 log units) below the measured one; the measured number falls inside the stated range.
By their numbers in this assay, from the lowest: compound 2; then compound 3; then compound 4; then compound 1.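

In this assay, among these compounds, methylsulfanyl in place of isopropoxy on an aromatic carbon gives a 3.0-fold lower number from compound 1 to compound 4 (0.48 log units; beyond the scatter) and so provides the first readable step at this position, with the amino group and the rest of the core kept as they are. The result shows that the number responds to the group held at this position, even though the exchange keeps one hydrogen-bond acceptor on each side, with no hydrogen-bond donor and no net charge. Two things change together, however: sulfur enters in place of oxygen, and the group falls from 4 heavy atoms to 2, and nothing available here bears on why the number moves.

The compounds shown leave open whether the heavy-atom count or the exchange of oxygen for sulfur accounts for the step, a question that methoxy or ethylsulfanyl at the same place would help to separate. Among the compounds shown here, they also leave open how far this step depends on the amino group, since no pair shows this exchange on a core carrying a hydrogen in its place.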